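The source may hold more compounds than are shown below. What is called first, only, known or untested is meant among the compounds shown, and "the series" means these compounds.

Measured in a functional assay on HCT-116 cells (Homo sapiens) for antiproliferative activity, read by sulforhodamine B assay; on this read-out higher numbers stand for weaker inhibition and lower numbers for stronger inhibition:
- compound 1 `CN1CCN(c2ccc(N/C=C3\C(=O)NC(=O)c4ccc(-n5cccc5)cc43)cc2)CC1`: 1500 nM
- compound 2 `O=C1NC(=O)c2ccc(-n3cccc3)cc2/C1=C/Nc1ccc(CN2CCCCC2)cc1`: 2700 nM
- compound 3 `CN1CCN(c2ccc(N/C=C3\C(=O)NC(=O)c4ccc(-c5ccsc5)cc43)cc2)CC1`: 1400 nM

Compound 2 gives 2700 nM, a value within the scatter of the values of the other two compounds, so the three do not separate. Next in view is compound 4 `O=C1NC(=O)c2ccc(-c3ccc(F)cc3)cc2/C1=C/Nc1ccc(CN2CCCCC2)cc1`, which keeps the (piperidin-1-yl)methyl group of compound 2 and carries 4-fluorophenyl in place of 1H-pyrrol-1-yl on an aromatic carbon.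

The closest measured step is the exchange of 1H-pyrrol-1-yl for thiophen-3-yl on the same aromatic carbon, a 1.1-fold lower number from compound 1 to compound 3 (0.03 log units; within the scatter). The other measured exchange, (piperidin-1-yl)methyl in place of 4-methylpiperazin-1-yl, is a 1.8-fold higher number from compound 1 to compound 2 (0.26 log units; within the scatter). Both stay small, but the evidence is thin. Among the measured compounds shown here, the first was measured with 4-methylpiperazin-1-yl present, and no measured compound carries 4-fluorophenyl or any six-membered aromatic ring at this place.

No shift beyond the scatter is therefore expected in this assay. The expected size is a 1.1-fold lower number from compound 2 to compound 4 (0.03 log units; within the scatter). The estimate for compound 4 is 2500 nM, with an expected range from 900 nM to 6500 nM.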

Compound 4, half-maximal inhibitory concentration: 1000 nM
Compound 4: middle estimate off by 2.5-fold (0.40 log units), on the high side; measured number inside the range.
By their numbers in this assay, from the lowest: compounds 4, 3, 1 and 2 (each within the scatter of the next, the first and the last beyond it).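

In this assay, among the compounds shown here, the aromatic carbon that carries the 1H-pyrrol-1-yl group now shows a response to its substituent: 4-fluorophenyl in place of 1H-pyrrol-1-yl gives a 2.7-fold lower number from compound 2 to compound 4 (0.43 log units; beyond the scatter) and is the first exchange at this place to lie beyond the scatter, though only modestly, while thiophen-3-yl in place of 1H-pyrrol-1-yl gave a 1.1-fold lower number from compound 1 to compound 3 (0.03 log units; within the scatter) on a compound carrying 4-methylpiperazin-1-yl. For the compounds shown here, the result also extends the substituents accepted at this place from five-membered aromatic rings with a hetero atom to a six-membered aromatic ring of carbon only, with no loss of activity in the one pair available, which carries the (piperidin-1-yl)methyl group. No measurement at hand bears on what lies behind this step, so it stands as an observation only.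

Open, going by these compounds, is whether the step depends on the fluorine, a question that an unsubstituted phenyl or a 4-methoxyphenyl group on the same aromatic carbon would address. Equally open is whether the step carries over to compounds with 4-methylpiperazin-1-yl; 4-fluorophenyl is shown here only together with (piperidin-1-yl)methyl.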